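This account rests on a few compounds, and the source may have more. Where it says the series, first, only, none or still open, it means among the compounds named here.

- compound 1 `CCCCCC(CCO)n1cnc2c(Cl)ncnc21`: > 50000 nM (a limit)
- compound 2 `CCCCCC(CCO)n1cnc2c(Cl)nc(Cl)nc21`: 6170 nM
- compound 3 `C=C(CO)C(CCCCC)n1cnc2c(Cl)ncnc21`: > 50000 nM (a limit)

All three compounds were tested in a functional assay on HCT-116 cells (Homo sapiens) for antiproliferative activity, read by MTT assay, with a stated time of 48 h; on this read-out lower numbers stand for stronger inhibition and higher numbers for weaker inhibition. Compound 1 gives > 50000 nM, which is a limit of the assay and not a number. Compound 3 gives > 50000 nM, and this too is a limit. Compound 1 therefore stands at the limit of > 50000 nM in this assay, at which 2 of the 3 values shown sit, with no measured number of its own.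

Compound 4 `CCCCCCCCCCCC(CCO)n1cnc2c(Cl)ncnc21` has not yet been measured. Its difference from compound 1 is hexyl in place of hydrogen on a saturated chain carbon, six bonds along the chain from an aromatic nitrogen. The change lies on the chain and leaves the shared core as it is.

Neither measured step makes this same change. The chloro change on an aromatic carbon gives an at least 8.1-fold lower number from compound 1 to compound 2 (0.90 log units; beyond the scatter). The change from 2-hydroxyethyl to 1-(hydroxymethyl)ethenyl gives a step that the two limits leave unreadable from compound 1 to compound 3. Compound 2 still shows that a single change can bring a measurable number, because an at least 8.1-fold lower number from compound 1 to compound 2 (0.90 log units; beyond the scatter) lies beyond the scatter. On that slender basis, a modest move toward lower numbers is expected, and another limit remains quite possible.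

The expected step reads an at least 2.5-fold lower number from compound 1 to compound 4 (0.39 log units; beyond the scatter). The estimate for compound 4 is 20000 nM, with an expected range from 6000 nM to 50000 nM.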

Compound 4, half-maximal inhibitory concentration: 7590 nM
Beside the measured number, compound 4's estimate is 2.6-fold (0.42 log units) above it; measured number inside the range.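

In this assay, hexyl in place of hydrogen on a saturated chain carbon, six bonds along the chain from an aromatic nitrogen, gives an at least 6.5-fold lower number from compound 1 to compound 4 (0.81 log units; beyond the scatter). Among these compounds, this is the first readable step for a change on the chain: the earlier readable step lay on an aromatic carbon, and the step from 2-hydroxyethyl to 1-(hydroxymethyl)ethenyl cannot be read. The shared core stays as it is, so the chain change alone brings a measured number here, but the size of the step is only a minimum, as one of its ends is a limit: the limit of > 50000 nM in this assay, at which 2 of the 4 values shown sit.

The compounds shown leave open how the number depends on chain length at this place, and whether a propyl, a decyl, or an amine or a carboxylic acid in place of the hexyl would give a lower or a higher number. They also leave open whether the hexyl change and the chloro change seen in compound 2 would add up when both stand in one structure.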